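Amide cap of the shared core: trifluoropropyl after cyclopropyl

A few compounds are considered here, and "the series" means these few. Any claim that something is new, unique, unknown or untested is made for them only; others in the source may bear on it.

Working notes on the series. Compound 1 `CCC(=O)N1C[C@@H]2C[C@H]1CN2C(=O)[C@@]1(C(C)C)CC[C@@H](NC2CCOCC2)C1` carries an ethyl on the carbonyl carbon of the amide on the shared core. In an in vitro ADME assay on microsomes from liver (Homo sapiens) for metabolic stability, tested at 1 uM (a lower number here means that the compound disappears faster, a higher number that the compound lasts longer), compound 1 gives > 2 h, which is a limit of the assay and not a number. Compound 2 `CC(C)[C@]1(C(=O)N2C[C@@H]3C[C@H]2CN3C(=O)C2CC2)CC[C@@H](NC2CCOCC2)C1` has cyclopropyl in place of ethyl on that carbonyl carbon. In this assay compound 2 gives > 2 h, again a limit and not a number. Among the compounds with values here, the step that the two limits leave unreadable from compound 1 to compound 2 therefore cannot be read; the two values show only that both compounds last to the end of the measured window, as noted in the limit of > 2 h in this assay, at which 2 of the 2 values shown sit.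

Compound 3 `CC(C)[C@]1(C(=O)N2C[C@@H]3C[C@H]2CN3C(=O)CCC(F)(F)F)CC[C@@H](NC2CCOCC2)C1` is the next member. The change from compound 2 is 3,3,3-trifluoropropyl in place of cyclopropyl on a carbonyl carbon. Within the data shown here, no measured step bears on it directly: the single measured step is unreadable in size, and both values known so far sit at the limit. Compound 2 stands at that limit and nowhere else on the numbers shown. With nothing pointing away from it, compound 3 is expected to reach the same region, an estimated 2.5 h, ranging from 0.8 h to 6 h. The step that the limit leaves unreadable from compound 2 to compound 3 is the expected outcome, a limit being the likeliest report.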

Compound 3, half-life: > 2 h
Compound 3 ended at the assay's limit; the forecaster's own chance of this, stated with the estimate: 65%; the middle value does not contradict the limit.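

In this assay compound 3 gives > 2 h, a limit of the assay and not a number. No step among compound 1, compound 2 and compound 3 can be read: the limit of > 2 h in this assay, at which 3 of the 3 values shown sit.

The compounds shown leave open whether ethyl, cyclopropyl and 3,3,3-trifluoropropyl on the carbonyl carbon differ at all in this assay.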